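This account rests on a few compounds, and the source may have more. Where it says the series, first, only, none or still open, it means among the compounds named here.

Compound 1 `CCN(CC)CCN1CCN(C(=O)COCCN(C)S(=O)(=O)c2c(C)cc(OC)cc2C)CC1` gives 7.8 in a functional assay on Umbilical vein for antagonist activity at B1 bradykinin receptor (Homo sapiens), using Schild analysis, with a stated time of 30 min (on this read-out lower numbers stand for lower potency and higher numbers for higher potency (the scale is a negative logarithm)), the second highest of three numbers. Compound 2 `COc1cc(C)c(S(=O)(=O)N(C)CCOCC(=O)N2CCC(C3CCN(C)CC3)CC2)c(C)c1` gives 9 in this assay, and compound 3 `COc1cc(C)c(S(=O)(=O)N(C)CCOCC(=O)N2CCC(C(C)(C)CN(C)C)CC2)c(C)c1` gives 7.5; compound 3 sits within the scatter of compound 1, while compound 2 stands clearly higher. Compound 4 `COc1cc(C)c(S(=O)(=O)N(C)CCOCC(=O)N2CCN(C3CCN(C4CC4)CC3)CC2)c(C)c1` differs from compound 1 by 1-cyclopropylpiperidin-4-yl in place of 2-(diethylamino)ethyl on an amine nitrogen in a ring. Among the measured compounds shown here, the one measured step that bears on this change runs the opposite way: a number 1.50 log units lower from compound 2 to compound 3 (beyond the scatter), a 1-methylpiperidin-4-yl replaced by an open-chain amine. Compound 4 brings a piperidinyl amine back in, and compound 2 carries such a group at 9. An upward step of a number 0.90 log units higher from compound 1 to compound 4 (beyond the scatter) is therefore expected. Compound 4 is estimated at 8.7, most likely between 8 and 9.4.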

Compound 4, negative logarithm of the antagonist equilibrium constant: 8.5
For compound 4 the middle estimate is 0.20 log units above the measured one, within the range that was stated.
By their numbers in this assay, from the lowest: compounds 3 and 1 (each within the scatter of the next); then compound 4; then compound 2.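

In this assay, the step of a number 0.70 log units higher from compound 1 to compound 4 (beyond the scatter) shows that on an amine nitrogen in a ring, too, a piperidinyl amine goes with a higher number than an open-chain amine, as it did on a saturated ring carbon in the step of a number 1.50 log units lower from compound 2 to compound 3 (beyond the scatter). Among the compounds shown, none goes against this, but it rests on only these two pairs. Nothing available gives a reason for the rise. The compounds shown do not separate the piperidine ring from the cyclopropyl on it. An unsubstituted piperidin-4-yl or a 1-isopropylpiperidin-4-yl on this nitrogen would bear on that question.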